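A few compounds are considered here, and "the series" means these few. Any claim that something is new, unique, unknown or untested is made for them only; others in the source may bear on it.

Of the compounds shown here, two that share one core have been measured in a functional assay on A-431 cells (Homo sapiens), tested at 0.1 uM; a higher number here means more inhibition at the concentration tested (going by the name of the read-out), a lower number less inhibition. Compound 1, `Fc1ccc(CNc2ncccc2-c2n[nH]c(Nc3ccc4c(c3)OCCO4)n2)cc1F`, gives 32%. Compound 2, `COc1cc(OC)cc(Oc2ncncc2-c2n[nH]c(Nc3ccc4c(c3)OCCO4)n2)c1`, gives 83%. Of these two numbers, compound 2 stands highest; its nearest neighbour is compound 1, whose number lies lower by a gap that is beyond the usual scatter of repeated measurements. Compound 3, `COc1cc(Nc2ncncc2-c2n[nH]c(Nc3ccc4c(c3)OCCO4)n2)cc(OC)c1`, has not been measured yet. It differs from compound 2 in one place: (3,5-dimethoxyphenyl)amino in place of 3,5-dimethoxyphenoxy on an aromatic carbon. Among the compounds with values here, no pair of measured compounds differing in only one place is available, so this change has no direct precedent, and compound 1, which carries a different core and a different side group, cannot serve as a guide. Since the ring bearing the two methoxy groups is kept and the change adds one hydrogen-bond donor while keeping the count of acceptors, the read-out is expected to stay close to that of compound 2. The expected step of a number 3 percentage points lower from compound 2 to compound 3 (within the scatter) is therefore within the usual scatter. Compound 3 is estimated at 80% in this assay, with a range from 58% to 95%.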

Compound 3, a percentage reported as inhibition, at one concentration (the size of the read-out at that concentration, not a potency): 68%
The estimate for compound 3 lay 12 percentage points above the measured number; the range from low to high includes it.
By their numbers in this assay, from the lowest: compound 1; then compound 3; then compound 2.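

In this assay, placing (3,5-dimethoxyphenyl)amino instead of 3,5-dimethoxyphenoxy on the aromatic carbon next to the ring nitrogen gives a number 15 percentage points lower from compound 2 to compound 3 (beyond the scatter). Within the data shown here, this is the first comparison in which only one place differs, and it shows that this position responds to a small edit: the two groups have the same heavy-atom count, the same carbon-only aromatic ring and the same number of hydrogen-bond acceptors, but the entering group has a nitrogen where the leaving group has an oxygen and adds one hydrogen-bond donor. The data include no measurement that explains the step, so they cannot show whether the added donor, the atom swap or something else is responsible.

Among these compounds, with only this one pair, it remains open whether the same step would appear with a side group other than the 3,5-dimethoxyphenyl ring. A methylamino link, with a methyl group on the connecting nitrogen, or a methylene link, with a plain carbon in that place, could help separate the effect of the added donor from that of the connecting atom.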